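From Butoxy to Nitro, Starting at a Limit

This account rests on a few compounds, and the source may have more. Where it says the series, first, only, none or still open, it means among the compounds named here.

In a functional assay on HCT-116 cells (Homo sapiens) for antiproliferative activity, with a stated time of 72 h (a higher number here means a weaker inhibitor, a lower number a stronger inhibitor), compound 1 `COc1ccc(/C=C/c2nc3ccccc3c(=O)[nH]2)cc1` gives > 25000 nM, which is a limit and not a number. Compound 2 `CCCCOc1ccc(/C=C/c2nc3ccccc3c(=O)[nH]2)cc1` gives > 25000 nM, which is also a limit. The evidence so far is the limit of > 25000 nM in this assay, at which 2 of the 2 values shown sit. For the measured compounds named here, the only measured step is a step that the two limits leave unreadable from compound 1 to compound 2, and it offers no size to carry forward.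

Compound 3 `O=c1[nH]c(/C=C/c2ccc([N+](=O)[O-])cc2)nc2ccccc12` carries nitro in place of butoxy on an aromatic carbon, para to a large group: nitro in place of butoxy on an aromatic carbon. Going by the values given here, no measured step involves this change. The expectation therefore starts from compound 2, whose > 25000 nM is a limit, and no clear gain in this assay is anticipated. The estimated step is an at least 1.2-fold lower number from compound 2 to compound 3 (0.09 log units; that floor lies within the scatter), a cautious figure. Compound 3 is expected at about 20000 nM, with an estimated range from 8000 nM to 25000 nM.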

Compound 3, half-maximal inhibitory concentration: > 25000 nM
Compound 3 was reported as a limit (the forecaster's own chance of this, stated with the estimate: 65%); middle value at least 1.2-fold (0.09 log units) from the limit.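

In this assay compound 3 gives > 25000 nM which is a limit and not a number, so no step can be read from it to compound 1 or compound 2. The compounds shown leave open how far these three differ, and whether any group at this place gives a readable value.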